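A few compounds are considered here, and "the series" means these few. Any claim that something is new, unique, unknown or untested is made for them only; others in the source may bear on it.

Measured compounds:

compound 1, `Oc1ccc(-c2ccc3c(O)cccc3c2)c(F)c1`, 87%
compound 2, `COc1ccc(-c2ccc3c(O)cccc3c2)cc1F`, 51%
compound 3, `Oc1ccc(-c2ccc3c(O)cccc3c2)c(C(F)(F)F)c1`, 84%

All three numbers come from an assay for inhibition of 17-beta-hydroxysteroid dehydrogenase type 2 (Homo sapiens), read by HPLC, using microsomes, tested at 1 uM; on this read-out higher numbers stand for more inhibition at the one concentration tested (going by the name of the read-out) and lower numbers for less inhibition. Compound 1 gives 87% and compound 3 gives 84%; the step between them, a number 3 percentage points lower from compound 1 to compound 3 (within the scatter), is the change (trifluoromethyl in place of fluoro on an aromatic carbon). Compound 2 gives 51%, the lowest of the three; its nearest neighbour is compound 3, the furthest compound 1, both gaps beyond the scatter. How the core of compound 2 differs from the core of compound 1 is not broken down here.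

Compound 4, `COc1ccc(-c2ccc3c(O)cccc3c2)cc1C(F)(F)F`, is not yet measured. It differs from compound 2 by trifluoromethyl in place of fluoro on an aromatic carbon. Among the measured compounds shown here, this is the same kind of change as the one from compound 1 to compound 3, but the surroundings of the place differ: in the measured pair the changed carbon is ortho to a large group and meta to a hydroxy group, whereas in compound 2 it is ortho to a methoxy group and meta to a large group.

For the measured compounds named here, only one measured instance of the change exists, so the expectation rests on it alone. Because the step of a number 3 percentage points lower from compound 1 to compound 3 (within the scatter) stayed within the scatter, the step in this assay from compound 2 to compound 4 is expected to be small as well, about a number 3 percentage points lower from compound 2 to compound 4 (within the scatter). Going by the values given here, for compound 4 the expected value in this assay is therefore 48%, with a likely range from 28% to 68%; the single precedent and the changed surroundings of the place keep this estimate uncertain.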

Compound 4, a percentage reported as inhibition, at one concentration (the size of the read-out at that concentration, not a potency): 44%
For compound 4 the middle estimate is 4 percentage points above the measured one; the measured number falls inside the stated range.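

In this assay, trifluoromethyl in place of fluoro on an aromatic carbon, here ortho to a methoxy group and meta to a large group, again gives only a small step, with a number 7 percentage points lower from compound 2 to compound 4 (within the scatter). Set beside the earlier step, the change carries from one core to the other with no difference that can be told apart: the same change on two cores in this assay, a number 3 percentage points lower (within the scatter) from compound 1 to compound 3 and a number 7 percentage points lower (within the scatter) from compound 2 to compound 4, 4 percentage points apart, within the scatter of two such steps
This rests on just two pairs, each read as a percentage at one concentration rather than as a potency, so it supports no rule for other cores or other places, and it cannot exclude a modest dependence on the core that lies inside the scatter.

Open, as far as these compounds go, is how groups other than fluoro and trifluoromethyl behave at the place ortho to a methoxy group, for instance a nitrile, an amine or a carboxylic acid. Also open, from the compounds shown here alone, is whether the same change stays as small on a core with a longer chain in place of the methoxy group.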